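Pyridin-3-yl to pyridin-2-yl: working notes on the series

A few compounds are considered here, and "the series" means these few. Any claim that something is new, unique, unknown or untested is made for them only; others in the source may bear on it.

Measured in an ADME assay on MRC5 cells (Homo sapiens) for cytotoxicity, read by fluorescence and resazurin assay, with a stated time of 3 days; on this read-out lower numbers stand for stronger inhibition and higher numbers for weaker inhibition:
compound 1 `Cc1cn(C2CCN(Cc3cccc(Oc4cc(Cl)cc(Cl)c4)c3)CC2)c(=O)[nH]c1=O`: 6730 nM
compound 2 `COc1ccc(Oc2cccc(CN3CCC(n4cc(C)c(=O)[nH]c4=O)CC3)c2)cc1`: 28000 nM
compound 3 `Cc1cn(C2CCN(Cc3cccc(Oc4cccnc4)c3)CC2)c(=O)[nH]c1=O`: > 64000 nM (a limit of the assay, not a number)

Compound 3 stands at the limit of > 64000 nM in this assay, at which 1 of the 3 values shown sits, and so is known by a limit only. The next structure, compound 4 `Cc1cn(C2CCN(Cc3cccc(Oc4ccccn4)c3)CC2)c(=O)[nH]c1=O`, has pyridin-2-yl in place of pyridin-3-yl on an oxygen on an aromatic ring. Among the compounds with values here, no measured step exchanges these two groups, so the nearest guides are the changes of the group on that same oxygen. These are a 4.2-fold higher number from compound 1 to compound 2 (0.62 log units; beyond the scatter), then an at least 9.5-fold higher number from compound 1 to compound 3 (0.97 log units; beyond the scatter) and an at least 2.2-fold higher number from compound 2 to compound 3 (0.35 log units; beyond the scatter), all beyond the scatter and all replacing one ring with a different kind of ring. Here the ring stays a six-membered aromatic ring with 1 hetero atom, so the change is narrower than in the steps that reach compound 3 (an at least 9.5-fold higher number from compound 1 to compound 3 (0.97 log units; beyond the scatter) and an at least 2.2-fold higher number from compound 2 to compound 3 (0.35 log units; beyond the scatter)). In this assay no step beyond the scatter is therefore expected, and if a direction appears, a lower number is the more likely one. The expected change is an at least 1.0-fold lower number from compound 3 to compound 4 (0.02 log units; that floor lies within the scatter) and remains an estimate. The estimate for compound 4 is 60000 nM (expected range 30000 nM to 120000 nM).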

Compound 4, half-maximal inhibitory concentration: > 64000 nM
Compound 4: a limit, no number (the forecaster's own chance of this, stated with the estimate: 55%); middle value at least 1.0-fold (0.02 log units) away from the limit.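

In this assay compound 4 gives > 64000 nM, a limit of the assay and not a number. Compound 3 and compound 4 therefore sit at the same limit, and the step between them cannot be read: the limit of > 64000 nM in this assay, at which 2 of the 4 values shown sit. Within the data shown here, what the earlier compounds did not show is that the high reading on this oxygen is not confined to pyridin-3-yl, since pyridin-2-yl also stands well clear of the two benzene-bearing compounds, with an at least 2.2-fold higher number from compound 2 to compound 4 (0.35 log units; beyond the scatter) and an at least 9.5-fold higher number from compound 1 to compound 4 (0.97 log units; beyond the scatter).

On these data alone, how far compound 3 and compound 4 lie past the limit, and whether they differ from each other at all, stays open, so no order can be given for the two pyridine isomers. Also open, as far as these compounds go, is whether the reading holds with pyridin-4-yl on the same oxygen, or whether a chlorine or a methoxy group on the pyridine ring would bring the number back towards those of compound 1 and compound 2.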